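The source may hold more compounds than are shown below. What is called first, only, known or untested is meant among the compounds shown, and "the series" means these compounds.

Compound 1 `O=C1/C(=C/c2ccccc2)CCC/C1=C\c1cccc(O)c1` gives 65.1% in an assay on isolated protein for inhibition of Alpha glucosidase (Homo sapiens), with stated times of 5 min and 15 min, tested at 50 uM; on this read-out lower numbers stand for less inhibition and higher numbers for more inhibition at the one concentration tested (going by the name of the read-out).
Compound 2 `O=C1/C(=C/c2ccccc2)CCC/C1=C\c1ccccc1F` gives 43% in this assay.
Compound 3 `Cc1cccc(/C=C2\CCC/C(=C\c3ccccc3)C2=O)c1` gives 47.9% in this assay.

Compound 3 stands second highest of the three: compound 1 is above it by a number 17.2 percentage points lower from compound 1 to compound 3 (beyond the scatter), while compound 2 differs from it only by a number 4.9 percentage points higher from compound 2 to compound 3 (within the scatter), within the scatter. Compound 4 `O=C1/C(=C/c2ccccc2)CCC/C1=C\c1ccccc1Br` is not yet measured; it differs from compound 3 by 2-bromophenyl in place of 3-methylphenyl on a double-bonded chain carbon bound to a double-bonded ring carbon. The step that bears on this is a number 4.9 percentage points higher from compound 2 to compound 3 (within the scatter), where a 3-methylphenyl replaced a 2-fluorophenyl, and the entering 2-bromophenyl resembles that 2-fluorophenyl. The larger step of a number 22.1 percentage points lower from compound 1 to compound 2 (beyond the scatter) involved a 3-hydroxyphenyl and does not bear directly here. The expected step from compound 3 is therefore a number 2.9 percentage points lower from compound 3 to compound 4 (within the scatter), within the scatter. The estimate for compound 4 in this assay is 45%, with a likely range from 30% to 60%.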

Compound 4, a percentage reported as inhibition, at one concentration (the size of the read-out at that concentration, not a potency): 46.8%
Compound 4: middle estimate off by 1.8 percentage points, on the low side; the range from low to high includes it.
By their numbers in this assay, from the lowest: compounds 2, 4 and 3 (each within the scatter of the next); then compound 1.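

Bromo in place of fluoro on an aromatic carbon gives a number 3.8 percentage points higher from compound 2 to compound 4 (within the scatter), so this assay does not tell these two halogens apart. The 2-bromophenyl and the 3-methylphenyl cannot be told apart either, at a number 1.1 percentage points lower from compound 3 to compound 4 (within the scatter). The 2-bromophenyl in place of the 3-hydroxyphenyl gives a number 18.3 percentage points lower from compound 1 to compound 4 (beyond the scatter), making this the third group without a hydroxy to stay clearly short of compound 1.

On these data alone, whether an amine or a carboxylic acid on the same ring could match the hydroxy remains open. Nothing available explains these numbers.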